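The source may report more compounds than this note shows. Statements on the series, on what has been measured and on what is new or still open speak of the compounds shown alone.

Compound 1 `Oc1ccc(-c2cc(-c3ccc(F)cc3)cc(-c3cccc(O)c3)n2)cc1` and compound 2 `Oc1ccc(-c2cc(-c3ccc(F)cc3)cc(-c3ccc(O)cc3)n2)cc1` share a core and differ in a single group. In a functional assay on HeLa cells (Homo sapiens) for inhibition (on this read-out lower numbers stand for stronger inhibition and higher numbers for weaker inhibition), compound 1 gives 8080 nM, and compound 2 gives 8680 nM. The change between them is 4-hydroxyphenyl in place of 3-hydroxyphenyl on an aromatic carbon, and it makes a 1.1-fold higher number from compound 1 to compound 2 (0.03 log units; within the scatter). Compound 3 `Oc1cccc(-c2cc(-c3ccc(OC(F)(F)F)cc3)cc(-c3cccc(O)c3)n2)c1` gives 18700 nM in this assay, the highest of the three numbers; the difference between its core and the core of compound 1 is not broken down here. Compound 4 `Oc1ccc(-c2cc(-c3ccc(OC(F)(F)F)cc3)cc(-c3cccc(O)c3)n2)cc1` has not yet been measured in this assay. It differs from compound 3 by 4-hydroxyphenyl in place of 3-hydroxyphenyl on an aromatic carbon. This is the same kind of change as that between compound 1 and compound 2, though the surroundings are not the same: in compound 1 the place is meta to a 4-fluorophenyl group and meta to a 4-hydroxyphenyl group, whereas in compound 3 it is meta to a 3-hydroxyphenyl group and meta to a large group. Because the same kind of change gave a 1.1-fold higher number from compound 1 to compound 2 (0.03 log units; within the scatter), the expected step is a 1.0-fold higher number from compound 3 to compound 4 (0.01 log units; within the scatter), a small one. Compound 4 is therefore estimated to give 19000 nM in this assay, with a range from 9000 nM to 40000 nM.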

Compound 4, half-maximal inhibitory concentration: 27800 nM
The estimate for compound 4 lay 1.5-fold (0.17 log units) below the measured number, within the range that was stated.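

In this assay, putting 4-hydroxyphenyl in place of 3-hydroxyphenyl on the core bearing trifluoromethoxy gives a 1.5-fold higher number from compound 3 to compound 4 (0.17 log units; within the scatter), and the two cores do not differ measurably in how they take this change: the same change on two cores in this assay, a 1.1-fold higher number (0.03 log units; within the scatter) from compound 1 to compound 2 and a 1.5-fold higher number (0.17 log units; within the scatter) from compound 3 to compound 4, 1.4-fold (0.14 log units) apart, within the scatter of two such steps. Going by these compounds alone, this shows that the swap carries across these two cores with neither step beyond the scatter, but it rests on only two pairs and does not show that the same would hold on any other core or for the other hydroxyphenyl group. Within the data shown here, the one step here that lies beyond the scatter belongs to a different change, trifluoromethoxy in place of fluoro, which gives a 3.4-fold higher number from compound 1 to compound 4 (0.54 log units; beyond the scatter); as a single pair, it says nothing about how that change would carry to another core.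

The compounds shown leave open what the hydroxyl groups contribute, such as how a methoxy group or an amine in their place would read. They also leave open how a chlorine or a methyl group would compare with fluoro and trifluoromethoxy on the shared core.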